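Ethoxy to (2-Chlorophenyl)amino on a Carbonyl: Compound 4

This account rests on a few compounds, and the source may have more. Where it says the series, first, only, none or still open, it means among the compounds named here.

Compound 1 `CCOC(=O)NC1CC(C)(C)Oc2ccc(Cl)cc21` is recorded in a functional assay on T98G cells (Homo sapiens) for inhibition, read by MTT assay, with a stated time of 72 h (a lower number here means a stronger inhibitor, a higher number a weaker inhibitor), as "not determined" (no result reported), so where it stands cannot be read from the data. Two relatives sharing its core have been measured. Compound 2 `CC(C)NC(=S)NC1CC(C)(C)Oc2ccc(Cl)cc21` gives 91000 nM in this assay. Compound 3 `CC1(C)CC(NC(=S)Nc2cccc([N+](=O)[O-])c2)c2cc(Cl)ccc2O1` gives 4000 nM in this assay, the lower of the two numbers. Compound 4 `CC1(C)CC(NC(=O)Nc2ccccc2Cl)c2cc(Cl)ccc2O1` differs from compound 1 in one place: (2-chlorophenyl)amino in place of ethoxy on a carbonyl carbon. Since compound 1 carries no value, neither the size nor the direction of the step to compound 4 in this assay can be stated, and any expectation must lean on what compounds 2 and 3 show. Compound 4 is expected to give roughly 8000 nM, most likely between 2000 nM and 40000 nM.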

Compound 4, half-maximal inhibitory concentration: 20000 nM
Compound 4: the middle estimate sits 2.5-fold (0.40 log units) below what was measured; measured number inside the range.
By their numbers in this assay, from the lowest: compound 3; then compound 4; then compound 2.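

In this assay, going by these compounds alone, compound 1 has no number, so no step to compound 4 can be read. Going by these compounds, what replacing ethoxy with (2-chlorophenyl)amino does to the result stays open. No evidence shown here bears on the value of compound 4.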